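A few compounds are considered here, and "the series" means these few. Any claim that something is new, unique, unknown or untested is made for them only; others in the source may bear on it.

Measured so far in an ADME assay on L02 cells (Homo sapiens) for cytotoxicity, read by MTT assay, with a stated time of 24 h; a lower number here means that less compound is tolerated, a higher number that more compound is tolerated:

Compound 1 `O=c1[nH]cc(S(=O)(=O)Nc2cccc(-c3cn(-c4ccccc4)nn3)c2)c(=O)[nH]1` gives > 100000 nM; this is a limit of the assay and not a number.

Compound 2 `Cc1ccccc1-n1cc(-c2cccc(NS(=O)(=O)c3c[nH]c(=O)[nH]c3=O)c2)nn1` gives 15300 nM.

Compound 3 `Cc1cccc(-n2cc(-c3cccc(NS(=O)(=O)c4c[nH]c(=O)[nH]c4=O)c3)nn2)c1` gives 28300 nM.

Compound 3 stands highest of the two numbers shown; its nearest neighbour is compound 2, and the difference between them, a 1.8-fold higher number from compound 2 to compound 3 (0.27 log units; within the scatter), stays within the scatter. Compound 1 sits at the limit of > 100000 nM in this assay, at which 1 of the 3 values shown sits, so only a limit separates it from the other two.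

Compound 4 `Cc1ccc(-n2cc(-c3cccc(NS(=O)(=O)c4c[nH]c(=O)[nH]c4=O)c3)nn2)cc1` has not been measured in this assay. It differs from compound 3 in one place: 4-methylphenyl in place of 3-methylphenyl on an aromatic nitrogen.

Two measured steps move a methyl around this ring. From compound 1 the steps of an at least 6.5-fold lower number from compound 1 to compound 2 (0.81 log units; beyond the scatter) and an at least 3.5-fold lower number from compound 1 to compound 3 (0.54 log units; beyond the scatter) are both beyond the scatter, each reaching a number below the limit. Between the two methyl isomers themselves, a 1.8-fold higher number from compound 2 to compound 3 (0.27 log units; within the scatter) lies within the scatter. Among the measured compounds shown here, the change to compound 4 shifts the methyl once more, and the closest precedent is that small step between compounds 2 and 3, so no step beyond the scatter is expected.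

Compound 4 is therefore expected near 25000 nM, with a range from 8000 nM to 75000 nM. That corresponds to an expected 1.1-fold lower number from compound 3 to compound 4 (0.05 log units; within the scatter), within the scatter.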

Compound 4, half-maximal cytotoxic concentration: 23100 nM
Compound 4: middle estimate off by 1.1-fold (0.03 log units), on the high side; measured number inside the range.
By their numbers in this assay, from the lowest: compounds 2, 4 and 3 (each within the scatter of the next). At a limit, above all of these: compound 1.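

In this assay, 4-methylphenyl adds a third methyl isomer on the aromatic nitrogen, and both a 1.2-fold lower number from compound 3 to compound 4 (0.09 log units; within the scatter) and a 1.5-fold higher number from compound 2 to compound 4 (0.18 log units; within the scatter) stay small, so moving the methyl around this ring produces no difference that can be read among compound 2, compound 3 and compound 4. The remaining step, an at least 4.3-fold lower number from compound 1 to compound 4 (0.63 log units; beyond the scatter), matches the two earlier steps from the plain phenyl of compound 1, so all three methyl compounds now stand apart from compound 1 whichever ring carbon carries the methyl. The value for compound 1 is a limit of the assay and not a number: the limit of > 100000 nM in this assay, at which 1 of the 4 values shown sits.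

The compounds shown leave open whether this separation from compound 1 belongs to methyl in particular or would also appear with another group on this ring, such as a chlorine, a methoxy, a carboxylic acid or a longer chain like propyl. With compound 1 at a limit, the true size of the change from hydrogen to methyl also stays open, as does any reason for it.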